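The source may report more compounds than this note shows. Statements on the series, on what has been measured and on what is new or still open speak of the compounds shown alone.

Of the compounds shown here, three that share one core have been measured in an in vitro functional assay on cells for agonist activity at Bombesin receptor subtype-3 (Mus musculus), read by luminescence and calcium flux; on this read-out higher numbers stand for an effect only at larger amounts of compound and lower numbers for an effect already at smaller amounts. Compound 1 `O=C(O)c1ccccc1-c1ccc(CCc2ncc(-c3ccccc3)[nH]2)cc1`, carrying a phenyl on an aromatic carbon, gives 872 nM. Compound 2 `CCC(C)(CC)Cc1cnc(CCc2ccc(-c3ccccc3C(=O)O)cc2)[nH]1` gives 30 nM, and compound 3 `O=C(O)c1ccccc1-c1ccc(CCc2ncc(Cc3cccc(F)c3F)[nH]2)cc1` gives 8 nM, the lowest number of the three. The steps of a 29-fold lower number from compound 1 to compound 2 (1.46 log units; beyond the scatter) and a 110-fold lower number from compound 1 to compound 3 (2.04 log units; beyond the scatter) were large, while a 3.8-fold lower number from compound 2 to compound 3 (0.57 log units; beyond the scatter) was modest. Compound 4 `COc1ccccc1Cc1cnc(CCc2ccc(-c3ccccc3C(=O)O)cc2)[nH]1` differs from compound 3 by 2-methoxyphenyl in place of 2,3-difluorophenyl on a saturated chain carbon bound to an aromatic carbon. Within the data shown here, this change sits at the same place as the modest step from compound 2 to compound 3, but no measured pair shows what swapping one substituted phenyl for another does there. For compound 3 to compound 4 only a modest shift is therefore expected, a 1.9-fold higher number from compound 3 to compound 4 (0.27 log units; within the scatter). Compound 4 is estimated at 15 nM, within 4 nM to 60 nM.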

Compound 4, half-maximal effective concentration: 163 nM
Beside the measured number, compound 4's estimate is 11-fold (1.04 log units) below it, outside the stated range (above it).
By their numbers in this assay, from the lowest: compound 3; then compound 2; then compound 4; then compound 1.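

With a 20-fold higher number from compound 3 to compound 4 (1.31 log units; beyond the scatter) this swap of one substituted phenyl for another proves large, so what the ring carries counts at this place, not just the ring itself. An aromatic ring here does not by itself give the lower number: a 5.4-fold higher number from compound 2 to compound 4 (0.74 log units; beyond the scatter) favours 1-ethyl-1-methylpropyl over 2-methoxyphenyl, while a 5.3-fold lower number from compound 1 to compound 4 (0.73 log units; beyond the scatter) still puts 2-methoxybenzyl ahead of phenyl. No measurement at hand explains these gaps. Still open, as far as these compounds go, is how a plain benzyl, with nothing on its ring, would read here, and so whether the fluorines or the methoxy sets the gap between compound 3 and compound 4.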